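Replacing the sulfonamide with a butylurea on the same nitrogen

This account rests on a few compounds, and the source may have more. Where it says the series, first, only, none or still open, it means among the compounds named here.

Compound 2 `CCCCc1ccc(CNS(C)(=O)=O)c(=O)n1Cc1ccc(-c2ccccc2-c2nn[nH]n2)cc1` has the lower of the two measured numbers. In a functional assay on the whole organism (artery) for inhibition, with Rattus norvegicus as the target, at a dose of 3 mg/kg by the intraduodenal route (a higher number here means more inhibition at the dose given (going by the name of the read-out), a lower number less inhibition), compound 2 gives 54.8%, while compound 1 `CCCCc1ccc(CN(C(C)C)S(C)(=O)=O)c(=O)n1Cc1ccc(-c2ccccc2-c2nn[nH]n2)cc1` gives 82.7%. Going by the values given here, the one measured step, a number 27.9 percentage points lower from compound 1 to compound 2 (beyond the scatter), is the only guide available. Compound 3 `CCCCNC(=O)NCc1ccc(CCCC)n(Cc2ccc(-c3ccccc3-c3nn[nH]n3)cc2)c1=O` is not yet measured; it differs from compound 2 by butylcarbamoyl in place of methylsulfonyl on an amine nitrogen. Among the compounds with values here, no measured pair shows this kind of change, so the step from compound 1 to compound 2 bears on it only loosely: it concerns the group on the same nitrogen, and there a larger group went with the higher number, compound 1 having the higher value 82.7%. Since the butylcarbamoyl group brings more atoms than the methylsulfonyl it replaces, a modest rise is expected, though a flat result or a fall cannot be ruled out. Compound 3 is therefore expected to reach about 62%, somewhere between 35% and 85%, which means an estimated a number 7.2 percentage points higher from compound 2 to compound 3 (within the scatter).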

Compound 3, a percentage reported as inhibition, in the whole organism at one dose (the size of the read-out at that dose, not a potency): 10.3%
The estimate for compound 3 lay 51.7 percentage points above the measured number; measured number below the stated range.
By their numbers in this assay, from the lowest: compound 3; then compound 2; then compound 1.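

In this assay, putting butylcarbamoyl in place of methylsulfonyl on the amine nitrogen gives a number 44.5 percentage points lower from compound 2 to compound 3 (beyond the scatter) and leaves compound 3 lowest of the three, so the larger group no longer goes with the higher number as it did for the isopropyl group of compound 1. Exchanging the whole isopropyl(methylsulfonyl)amino group for (butylcarbamoyl)amino gives a number 72.4 percentage points lower from compound 1 to compound 3 (beyond the scatter) and shows that, with the rest of the structure held constant, the groups at this position span a wide range of inhibition in this assay at this dose. Nothing measured here explains the fall.

The swap changes the sulfonyl link to a carbonyl-based urea and the methyl to a butyl chain at once, so a methylcarbamoyl or a butylsulfonyl group on the same nitrogen would be needed to separate the two changes. From the compounds shown here alone, it also remains open whether an isopropyl group on this nitrogen of the urea would go with a higher number, as it does in the sulfonamide pair.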